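The source may hold more compounds than are shown below. What is called first, only, known or untested is meant among the compounds shown, and "the series" means these compounds.

Measured so far in an ADME assay on PANC-1 cells (Homo sapiens) for cytotoxicity, read by MTT assay, with a stated time of 48 h; a higher number here means a weaker inhibitor of growth, a lower number a stronger inhibitor of growth:
- compound 1 `O=C(/C=C\c1cccc(F)c1)N1N=C(c2ccncc2)OC1c1c[nH]c2ccccc12` gives > 30 ug/mL
- compound 2 `O=C(/C=C\c1ccc(F)cc1)N1N=C(c2ccncc2)OC1c1c[nH]c2ccccc12` gives > 30 ug/mL

Compound 2 stands only at a limit: its value of > 30 ug/mL in this assay is the upper edge of what was tested, not a measured number. Compound 1 likewise sits at a limit, > 30 ug/mL. Both values rest at the limit of > 30 ug/mL in this assay, at which 2 of the 2 values shown sit, so neither compound shows measurable growth inhibition within the tested range. Among the measured compounds shown here, the one measured step between them, a step that the two limits leave unreadable from compound 1 to compound 2, is left unreadable by the two limits, so moving the fluorine around the phenyl ring tells nothing about size or direction.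

Compound 3 is `O=C(/C=C\c1cccc(Cl)c1Cl)N1N=C(c2ccncc2)OC1c1c[nH]c2ccccc12`. It differs from compound 2 in one place: 2,3-dichlorophenyl in place of 4-fluorophenyl on a double-bonded chain carbon bound to a double-bonded chain carbon. For the measured compounds named here, no measured step bears on this exchange, and the only step on record is itself unreadable. The expectation for compound 3 in this assay therefore rests on the two limits alone, and the step of a number no higher from compound 2 to compound 3 (the limit leaves the size open) is expected to be none beyond the scatter. Compound 3 is estimated at 30 ug/mL, with a range from 10 ug/mL to 90 ug/mL, and most likely again only a limit.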

Compound 3, concentration for 50% growth inhibition: > 30 ug/mL
Compound 3 gave a limit, no number; the forecaster's own chance of this, stated with the estimate: 70%; the middle value sits exactly at the limit.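

In this assay compound 3 gives > 30 ug/mL, a limit and not a number. No step linking compound 3 to compound 1 or compound 2 can be read, because all three compounds rest at the same edge: the limit of > 30 ug/mL in this assay, at which 3 of the 3 values shown sit.

The compounds shown leave open how far apart the three truly lie, and whether any other phenyl substitution would give a measurable value.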